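Chloro for Methyl on Two Related Quaternary Ammonium Series

This account rests on a few compounds, and the source may have more. Where it says the series, first, only, none or still open, it means among the compounds named here.

Measured so far:
compound 1, `CC[N+]1(CCCCCCCOc2ccc(-n3cc(C(=O)Nc4cc(F)cc(F)c4)c(=O)c4ccc(N(C)C)nc43)cc2C)CCCCC1`, 19.7%
compound 2, `CC[N+]1(CCCCCCCOc2ccc(-n3cc(C(=O)Nc4cc(F)cc(F)c4)c(=O)c4ccc(N(C)C)nc43)cc2Cl)CCCCC1`, 14.3%
compound 3, `Cc1ccc(-n2cc(C(=O)Nc3cc(F)cc(F)c3)c(=O)c3ccc(N(C)C)nc32)cc1OCCCCCCC[N+]1(C)CCN(C)CC1`, 10.4%

In an assay on LX2 cells for inhibition of COL1A1 promoter (Homo sapiens), read by a luciferase reporter, with a stated time of 24 h, tested at 20 uM (on this read-out lower numbers stand for a weaker effect and higher numbers for a stronger effect at the one concentration tested), compound 1 gives 19.7% and compound 2 gives 14.3%. The change between them is chloro in place of methyl on an aromatic carbon, and it made a number 5.4 percentage points lower from compound 1 to compound 2 (within the scatter). Compound 3, in this assay, gives 10.4%; the difference between its core and the core of compound 1 is not broken down here. Compound 4, `CN1CC[N+](C)(CCCCCCCOc2cc(-n3cc(C(=O)Nc4cc(F)cc(F)c4)c(=O)c4ccc(N(C)C)nc43)ccc2Cl)CC1`, has not yet been measured; it differs from compound 3 by chloro in place of methyl on an aromatic carbon. This is the same kind of change as from compound 1 to compound 2, though there the place was meta to a large group, here it is para to a large group. Because a number 5.4 percentage points lower from compound 1 to compound 2 (within the scatter) was small, compound 4 is expected to move by about a number 4.4 percentage points lower from compound 3 to compound 4 (within the scatter). The estimate for compound 4 in this assay is 6%, between -3% and 15%.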

Compound 4, a percentage reported as inhibition, at one concentration (the size of the read-out at that concentration, not a potency): 27.5%
Estimate against measurement, compound 4: 21.5 percentage points below, outside the stated range (above it).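

In this assay, chloro in place of methyl on an aromatic carbon gave a number 17.1 percentage points higher from compound 3 to compound 4 (beyond the scatter), and this result did not match the one on the other core: the same change on two cores in this assay, a number 5.4 percentage points lower (within the scatter) from compound 1 to compound 2 and a number 17.1 percentage points higher (beyond the scatter) from compound 3 to compound 4, 22.5 percentage points apart, beyond the scatter of two such steps The step seen on one core was therefore no reliable guide to the step on the other within these two pairs. What this does not show is which difference between the two cores sets the steps apart, and two pairs give no general rule for the series.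

The compounds shown leave open whether fluoro or bromo at the same place on the core of compound 3 would behave as chloro does. They also leave open whether the step would persist with a shorter chain.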